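The source may report more compounds than this note shows. Statements on the series, on what has been measured and on what is new or still open speak of the compounds shown alone.

Three compounds of the series have so far been run in a functional assay on MCF7 cells (Homo sapiens) for cytotoxicity, read by CCK-8 assay, with a stated time of 72 h; a higher number here means a weaker inhibitor, a lower number a stronger inhibitor. Compound 1 `NC(=S)/N=C1/C=C[C@H]2CO[C@@H]1O2` returns only a limit, > 1000000 nM. Compound 2 `NC(=S)/N=C1/CC[C@H]2CO[C@@H]1O2` likewise returns only a limit, > 1000000 nM. Compound 3 `CC(=O)O[C@@H]1[C@@H](OC(C)=O)[C@H](S[C@@H]2C/C(=N/C(N)=S)[C@@H]3OC[C@H]2O3)OC[C@@H]1OC(C)=O` also gives only a limit, > 1000000 nM. Compound 3 thus stands where the other two stand, and nothing separates it from them, since (the limit of > 1000000 nM in this assay, at which 3 of the 3 values shown sit). Going by the values given here, no pair of the measured compounds differs in a single place, so no measured step exists in this set.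

Compound 4 `CC(=O)OC[C@H]1O[C@@H](S[C@@H]2C/C(=N/C(N)=S)[C@@H]3OC[C@H]2O3)[C@H](OC(C)=O)[C@@H](OC(C)=O)[C@H]1OC(C)=O` is the next entry. It differs from compound 3 by acetoxymethyl in place of hydrogen on a saturated ring carbon. Among the compounds with values here, with every measured value sitting at the limit, there is no measured step to scale this change against. The expected step is a number no higher from compound 3 to compound 4 (the limit leaves the size open), meaning no movement beyond the usual scatter. Compound 4 is therefore estimated at 1000000 nM in this assay, within 200000 nM to 5000000 nM, with a strong chance that once more only a limit is reported.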

Compound 4, half-maximal inhibitory concentration: > 1000000 nM
Compound 4: no number, only a limit; the forecaster's own chance of this, stated with the estimate: 85%; the middle value sits exactly at the limit.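

No step can be read from compound 3 to compound 4, since both results are limits and not numbers: the limit of > 1000000 nM in this assay, at which 4 of the 4 values shown sit.

The compounds shown leave open whether acetoxymethyl in place of hydrogen on a saturated ring carbon, or any other change to the series, alters the read-out in this assay.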